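The source may hold more compounds than are shown below. What is called first, only, known or untested is meant among the compounds shown, and "the series" means these compounds.

Compound 3, `O=c1nc(-c2ccccc2)c2cc(-c3cc[nH]n3)ccc2[nH]1`, belongs to a small set of three measured compounds sharing one core. In an ADME assay on L6 cells (Rattus norvegicus) for cytotoxicity, read by fluorescence and resazurin assay, with a stated time of 72 h (a lower number here means that less compound is needed, a higher number that more compound is needed for the effect), compound 3 gives > 50000 nM, which is a limit of the assay rather than a number. Its relatives are compound 1, `O=c1nc(-c2ccccc2)c2cc(-c3ccccc3)ccc2[nH]1`, and compound 2, `O=c1nc(-c2ccccc2)c2cc(-c3ccc(F)cc3)ccc2[nH]1`. In this assay compound 1 gives > 50000 nM, again a limit. In this assay compound 2 gives 50000 nM. Compound 3 thus sits at the limit of > 50000 nM in this assay, at which 2 of the 3 values shown sit, as does compound 1. Compound 2 reports its figure as a number rather than a limit. The step that the two limits leave unreadable from compound 1 to compound 3 and the step of a number no lower from compound 2 to compound 3 (the limit leaves the size open) therefore cannot be sized. Compound 4, `Cn1nccc1-c1ccc2[nH]c(=O)nc(-c3ccccc3)c2c1`, differs from compound 3 in one place: 1-methyl-1H-pyrazol-5-yl in place of 1H-pyrazol-3-yl on an aromatic carbon. Among the measured compounds shown here, no measured step covers this exact change, and the two steps leading to compound 3 are unreadable, so no direction beyond the scatter can be read from them. The step of a number no higher from compound 3 to compound 4 (the limit leaves the size open) is expected to be small. In this assay compound 4 is estimated at 50000 nM, within a range from 25000 nM to 100000 nM, and most likely reported only as a limit.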

Compound 4, half-maximal effective concentration: > 50000 nM
Compound 4: only a limit was reported; the forecaster's own chance of this, stated with the estimate: 75%; the middle value sits exactly at the limit.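

In this assay compound 4 also gives only a limit, so putting 1-methyl-1H-pyrazol-5-yl at this position on the six-membered aromatic ring yields no readable number, just as 1H-pyrazol-3-yl did. Among the compounds shown here, the one step with a direction is a number no lower from compound 2 to compound 4 (the limit leaves the size open), while the steps to compound 4 from compound 1 and compound 3 cannot be read. The new result adds one more compound to the group at the limit: the limit of > 50000 nM in this assay, at which 3 of the 4 values shown sit.

The compounds shown therefore leave open how much this change alters the value, since that would take numbers rather than limits. They also leave open whether a quite different group at this position, such as an amine or a carboxylic acid, would give a value clearly lower than those seen here.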